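Replacing a cyclopentyl carbamate with a 3-fluorophenyl one

The compounds below may be only part of what the source reports. "The series", "measured", "known", "first", "only" and "open" are said of these compounds alone.

Measured so far:
- compound 1, `Cc1ccc(C(C)C)c(OC(=O)Nc2ccc([N+](=O)[O-])cc2)c1`, 57.8%
- compound 2, `Cc1ccc(C(C)C)cc1OC(=O)NC1CCCC1`, 75.6%

Two carbamates have been tested in a toxicity assay on the whole organism (H4IIE cells) for cytotoxicity, with Rattus norvegicus as the target, read by MTT assay, with a stated time of 24 h, tested at 0.15 uM; a higher number here means a weaker effect of the compound at the concentration tested, a lower number a stronger effect. In this assay compound 1 gives 57.8%, while compound 2 gives 75.6%. Compound 2 thus holds the highest of the two numbers, meaning the weaker effect at the concentration tested; its nearest neighbour is compound 1, whose number is lower by a gap that is beyond the usual scatter. Within the data shown here, no step between compounds differing in a single place has been measured, so nothing can yet be said about what any one change does.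

The next compound, compound 3, is `Cc1ccc(C(C)C)cc1OC(=O)Nc1cccc(F)c1`. Compared with compound 2 the change is 3-fluorophenyl in place of cyclopentyl on an amide-type nitrogen. Among the measured compounds shown here, the only guidance comes from the other compound that carries an aromatic ring on that nitrogen: in this assay compound 1 gives 57.8%, a value that sits below that of compound 2. A modest drop in the number is therefore expected, though it may well stay within the scatter. For compound 3 the expected value in this assay is 66%, with a range from 50% to 82%. This estimate corresponds to an expected step of a number 9.6 percentage points lower from compound 2 to compound 3 (within the scatter).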

Compound 3, a percentage reported as activity, at one concentration (the size of the read-out at that concentration, not a potency): 90%
Compound 3: the middle estimate sits 24 percentage points below what was measured; measured number above the stated range.
By their numbers in this assay, from the lowest: compound 1; then compound 2; then compound 3.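

In this assay, among these compounds, the group on the amide-type nitrogen now has an effect that can be read on its own: the step is a number 14.4 percentage points higher from compound 2 to compound 3 (beyond the scatter) and it is the only change between these two compounds. An aromatic ring at this place therefore does not have to bring the number down, and with 3-fluorophenyl in place of cyclopentyl the effect at the concentration tested becomes weaker, not stronger. Compound 1 differs from compound 3 in more than one place, so its lower number cannot be credited to an aromatic ring on that nitrogen, and no measurement here bears on why the swap raises the number.

Whether this step belongs to the aromatic ring as such or to its fluorine stays open, as a plain phenyl group on that nitrogen is not among the compounds shown. Also open is how a cyclohexyl group, or a 3-chlorophenyl group, would read at this place, and whether the same step would hold at other concentrations, as only one concentration is shown here.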